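This account rests on a few compounds, and the source may have more. Where it says the series, first, only, none or still open, it means among the compounds named here.

Measured compounds:
Compound 1, `COC(=O)c1c(Nc2ccccc2)sc(C(=O)c2ccc(OC)cc2)c1C` — 48.1%
Compound 2, `COC(=O)c1c(Nc2ccccc2)sc(C(=O)c2ccc(C)cc2)c1C` — 9.35%
Compound 3, `COc1ccc(C(=O)c2sc(Nc3ccc(C)cc3)c(C(=O)O)c2C)cc1` — "not active" (no number reported)

In a functional assay, with a stated time of 150 min, tested at 30 ug/mL (on this read-out lower numbers stand for a weaker effect and higher numbers for a stronger effect at the one concentration tested), compound 1 gives 48.1%, while compound 2 gives 9.35%. The two differ by one change, (methoxy in place of methyl on an aromatic carbon), and that change made a step of a number 38.8 percentage points higher from compound 2 to compound 1 (beyond the scatter). Compound 3 is reported in this assay as "not active" (no number reported), with no number attached. How the core of compound 3 differs from the core of compound 2 is not broken down here.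

Compound 4, `COc1ccc(Nc2sc(C(=O)c3ccc(OC)cc3)c(C)c2C(=O)O)cc1`, has not yet been measured. It differs from compound 3 by methoxy in place of methyl on an aromatic carbon. Among the measured compounds shown here, this is the same change as the one from compound 2 to compound 1, and the place is described in the same words, so the change is the same kind of change made on a different core. For the measured compounds named here, the only guide to its size is the step of a number 38.8 percentage points higher from compound 2 to compound 1 (beyond the scatter), seen once, on a core whose relation to that of compound 3 is not counted out.

Compound 4 is therefore expected to show a clearly stronger read-out than compound 3 in this assay, because of the step of a number 38.8 percentage points higher from compound 2 to compound 1 (beyond the scatter), but with a starting point that carries no number the size of the rise is uncertain, and the estimate for compound 4 is 18%, between 0% and 45%.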

Compound 4, a percentage reported as activity, at one concentration (the size of the read-out at that concentration, not a potency): 41.2%
For compound 4 the middle estimate is 23.2 percentage points below the measured one; the range from low to high includes it.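

Among the compounds shown here, compound 4 gives 41.2% in this assay, but compound 3 is reported there without a number, so no step between compound 3 and compound 4 can be read. The compounds shown leave open how large the change from methyl to methoxy is on the core of compound 3. No evidence here bears on the read-out of compound 4.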